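Thiourea series: from compound 2 to compound 3

This account rests on a few compounds, and the source may have more. Where it says the series, first, only, none or still open, it means among the compounds named here.

compound 1 `FC(F)(F)c1cnc(N2CCC(NC(=S)Nc3cccnc3)CC2)c(Cl)c1` 89%
compound 2 `FC(F)(F)c1cnc(N2CCC(NC(=S)N3CCCc4ccccc43)CC2)c(Cl)c1` 0%

In an assay on membranes from brain for binding affinity to Lysophosphatidylserine lipase ABHD12 (Mus musculus), read by fluorescence, with a stated time of 20 min, tested at 2 uM (a lower number here means a weaker effect, a higher number a stronger effect of the compound at the concentration tested), compound 1 gives 89%, while compound 2 gives 0%, the lowest of the two numbers shown. Among the compounds with values here, the one measured step, a number 89 percentage points lower from compound 1 to compound 2 (beyond the scatter), bears directly on the next change. Compound 3 `COc1ccc(NC(=S)NC2CCN(c3ncc(C(F)(F)F)cc3Cl)CC2)cn1` differs from compound 2 as follows: (6-methoxypyridin-3-yl)amino in place of 1,2,3,4-tetrahydroquinolin-1-yl on a thiocarbonyl carbon. This returns an amino-linked aromatic group to the thiocarbonyl carbon, much as in compound 1, so a large rise a number 80 percentage points higher from compound 2 to compound 3 (beyond the scatter) is expected, reversing most of the earlier loss. Compound 3 is estimated at 80%, with a range of 55% to 95%.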

Compound 3, a percentage reported as inhibition, at one concentration (the size of the read-out at that concentration, not a potency): 0%
Estimate against measurement, compound 3: 80 percentage points above, and the stated range ends above it.
By their numbers in this assay, from the lowest: compounds 2 and 3 (each within the scatter of the next); then compound 1.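

In this assay, methoxy in place of hydrogen on an aromatic carbon gives a number 89 percentage points lower from compound 1 to compound 3 (beyond the scatter), so this single change is enough to remove the read-out, even with the amino link to the thiocarbonyl carbon retained. The other comparison gives no change at the digits printed from compound 2 to compound 3 (within the scatter), so an amino-linked aromatic group does not by itself preserve inhibition. Nothing measured here accounts for the loss. Still open, from the compounds shown here alone, is whether a fluorine, a methyl or a hydroxy group on that aromatic carbon would retain the inhibition seen with compound 1.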